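The compounds below may be only part of what the source reports. "The series", "measured", "known", "first", "only" and "open" are said of these compounds alone.

In a functional assay on KB cells (Homo sapiens) for inhibition, read by sulforhodamine B assay (on this read-out higher numbers stand for weaker inhibition of growth and lower numbers for stronger inhibition of growth), compound 1 (`Cc1ccc2[nH]c(-c3ccc(-c4ccc(-c5ccc(F)cc5)cc4)cc3)nc2c1`) gives 24900 nM and compound 2 (`Cc1ccc2[nH]c(-c3ccc(-c4ccc(-c5ccc(OC(F)(F)F)cc5)cc4)cc3)nc2c1`) gives 41200 nM so the two stand within the scatter of each other. Compound 3 (`Cc1ccc2[nH]c(-c3ccc(-c4ccc(-c5ccc(O)cc5)cc4)cc3)nc2c1`) differs from compound 2 at one place (hydrogen in place of trifluoromethyl on an oxygen on an aromatic ring) with hydrogen in place of trifluoromethyl on an oxygen on an aromatic ring. Within the data shown here, the only measured step (a 1.7-fold higher number from compound 1 to compound 2 (0.22 log units; within the scatter)) put trifluoromethoxy in place of fluoro and stayed within the scatter. That step does not test a hydroxy group directly, so it is only a weak guide, and no change beyond the scatter is expected in this assay here. The estimated step (a 1.5-fold lower number from compound 2 to compound 3 (0.17 log units; within the scatter)) is therefore small. Compound 3 is expected at 28000 nM with 9000 nM to 70000 nM as the estimated range.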

Compound 3, concentration for 50% growth inhibition: 21200 nM
Compound 3: the middle estimate sits 1.3-fold (0.12 log units) above what was measured; the range from low to high includes it.
By their numbers in this assay, from the lowest: compounds 3, 1 and 2 (each within the scatter of the next).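

Swapping the trifluoromethyl on the oxygen for hydrogen (a 1.9-fold lower number from compound 2 to compound 3 (0.29 log units; within the scatter)) leaves the result in this assay within the scatter, and so does hydroxy in place of fluoro (a 1.2-fold lower number from compound 1 to compound 3 (0.07 log units; within the scatter)). This place on the aromatic ring has now carried fluoro, trifluoromethoxy and hydroxy, and the three compounds all stand within the scatter of one another. No other measurement shown here bears on this result.

As far as these compounds go, whether an amine or a carboxylic acid at this place would move the number beyond the scatter stays open. So does the effect of changes elsewhere on the shared core.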